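The compounds below may be only part of what the source reports. "The series", "measured", "known", "first", "only" and "open" are said of these compounds alone.

Measured in a functional assay on PC-3 cells (Homo sapiens) for cytotoxicity, read by MTT assay, with a stated time of 48 h; on this read-out higher numbers stand for weaker inhibition and lower numbers for stronger inhibition:
- compound 1 `O=C1C=CC[C@H](c2cccc3ccccc23)O1`: 800 nM
- compound 2 `Cc1ccc2ccccc2c1[C@H]1CC=CC(=O)O1`: 130 nM

Compound 1 has the higher of the two numbers, so it is the weaker inhibitor. Compound 3 `Cc1ccc([C@H]2CC=CC(=O)O2)c2ccccc12` differs from it by methyl in place of hydrogen on an aromatic carbon, with the methyl para to a group of 7 heavy atoms. Going by the values given here, one measured step bears on this: a 6.2-fold lower number from compound 1 to compound 2 (0.79 log units; beyond the scatter), the same replacement at a different carbon. A lower number in this assay is therefore expected, though a single step at another place gives only weak support, and a smaller step is assumed. The expected step is a 2.7-fold lower number from compound 1 to compound 3 (0.43 log units; beyond the scatter). For compound 3 the estimated value is 300 nM, with an expected range of 100 nM to 900 nM.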

Compound 3, half-maximal inhibitory concentration: 50 nM
Beside the measured number, compound 3's estimate is 6.0-fold (0.78 log units) above it; measured number below the stated range.
By their numbers in this assay, from the lowest: compound 3; then compound 2; then compound 1.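

In this assay methyl in place of hydrogen, para to a group of 7 heavy atoms, gives a 16-fold lower number from compound 1 to compound 3 (1.20 log units; beyond the scatter) against a 6.2-fold lower number from compound 1 to compound 2 (0.79 log units; beyond the scatter) for the same replacement at a different carbon. The number falls with methyl at both carbons, and the size of the step differs with the carbon that carries it. Nothing available here accounts for that difference in size. Going by these compounds, whether this carbon also accepts a larger or different group, such as ethyl, methoxy, chlorine or an amine, stays open. On these data alone, whether the two methyl groups together lower the number further also stays open.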